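A few compounds are considered here, and "the series" means these few. Any claim that something is new, unique, unknown or untested is made for them only; others in the source may bear on it.

Compound 1 `O=C(c1ccccc1)c1cccc(NS(=O)(=O)c2ccc(Br)cc2)c1` and compound 2 `O=C(c1ccccc1)c1ccc(NS(=O)(=O)c2ccc(Br)cc2)cc1` are built from the same atoms joined differently; the difference between their two cores is not broken down here. In an assay on CHO cells for binding affinity to integrin alpha-1 (Homo sapiens), read by WST assay, with a stated time of 2 h, tested at 50 uM (on this read-out lower numbers stand for less inhibition and higher numbers for more inhibition at the one concentration tested (going by the name of the read-out)), compound 1 gives 92%, while compound 2 gives 34%. The change iodo in place of bromo on an aromatic carbon leads to compound 3 `O=C(c1ccccc1)c1ccc(NS(=O)(=O)c2ccc(I)cc2)cc1`, which gives 85% in this assay, a step of a number 51 percentage points higher from compound 2 to compound 3 (beyond the scatter). Compound 4 `O=C(c1ccccc1)c1cccc(NS(=O)(=O)c2ccc(I)cc2)c1` has not yet been measured; it differs from compound 1 by iodo in place of bromo on an aromatic carbon, the same change made at the same place. Because compound 1 already stands at 92%, little room remains for a rise, so a far smaller step than the earlier one is expected, namely a number 1 percentage points higher from compound 1 to compound 4 (within the scatter). Compound 4 is accordingly estimated at 93%, most likely between 84% and 99%.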

Compound 4, a percentage reported as inhibition, at one concentration (the size of the read-out at that concentration, not a potency): 72%
Compound 4: the middle estimate sits 21 percentage points above what was measured; measured number outside the range, below it.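

In this assay, iodo in place of bromo gives a step of a number 20 percentage points lower from compound 1 to compound 4 (beyond the scatter) on the core of compound 1, so the rise seen on the other core does not carry over. This shows that, for these two pairs, a step read on one core cannot simply be transferred to the other; it does not show why the cores differ, nor does it give a rule for any further core. The two steps set side by side read: the same change on two cores in this assay, a number 51 percentage points higher (beyond the scatter) from compound 2 to compound 3 and a number 20 percentage points lower (beyond the scatter) from compound 1 to compound 4, 71 percentage points apart, beyond the scatter of two such steps

As far as these compounds go, how chloro, a methoxy group, an amine or a carboxylic acid would behave in the same place on each core remains open. So does whether the benzoyl group can be exchanged.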